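A few compounds are considered here, and "the series" means these few. Any claim that something is new, unique, unknown or untested is made for them only; others in the source may bear on it.

Working notes on the cytotoxicity series. Compound 1 `C=C[C@@](C)(/C=C/c1ccc(OCc2ccccc2)cc1)CCC=C(C)C` is the reference point. In an ADME assay on BJ cells (Homo sapiens) for cytotoxicity, with a stated time of 72 h (on this read-out higher numbers stand for an effect only at larger amounts of compound and lower numbers for an effect already at smaller amounts), compound 1 gives > 36600 nM, which is a limit of the assay rather than a number. Compound 2 `C=C[C@@](C)(/C=C/c1ccc(O)cc1)CC/C=C/C#N` gives > 36600 nM in this assay, again a limit. Compound 3 `C=C[C@@](C)(/C=C/c1ccc(Nc2ccc(OC(F)(F)F)cc2)cc1)CCC=C(C)C` gives > 36600 nM in this assay, also a limit. Across the measured set, then, the limit of > 36600 nM in this assay, at which 3 of the 3 values shown sit, holds for every compound, so compound 1 stands level with compounds 2 and 3 as far as these limits show, and no ordering among the three can be read from the numbers.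

Compound 4 `C=C[C@@](C)(/C=C/c1ccc(-c2ccc(F)cc2)cc1)CCC=C(C)C` has not yet been measured in this assay. It differs from compound 1 by 4-fluorophenyl in place of benzyloxy on an aromatic carbon. With every measured compound sitting at the limit, no step beyond the scatter is expected, and the step that the limit leaves unreadable from compound 1 to compound 4 is estimated to be nil. For compound 4 the expected value in this assay is 50000 nM, with a range from 20000 nM to 150000 nM, most likely reported again only as a limit.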

Compound 4, half-maximal effective concentration: > 36600 nM
Compound 4: a limit, no number; the forecaster's own chance of this, stated with the estimate: 80%; the middle value does not contradict the limit.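

No step from compound 1 to compound 4 can be read, since both results are only limits of the assay: the limit of > 36600 nM in this assay, at which 4 of the 4 values shown sit.

The compounds shown leave open where any of them would reach a half-maximal effect in this assay, and so whether 4-fluorophenyl in place of benzyloxy changes anything there.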